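The compounds below may be only part of what the source reports. "The series", "measured", "known", "first", "only" and "open" are said of these compounds alone.

Measured compounds in the series:
- compound 1, `CCc1cc(NC(=O)Nc2cccc(C(F)(F)F)c2)cc(Cl)c1Oc1cc(NC)ncn1`: <= 10 nM
- compound 2, `CCCNc1cc(Oc2ccc(NC(=O)Nc3cccc(C(F)(F)F)c3)cc2)ncn1`: 32 nM
- compound 3, `CNc1cc(Oc2ccc(NC(=O)Nc3cccc(CF)c3)cc2)ncn1`: 400 nM

In an assay on isolated protein for inhibition of serine/threonine-protein kinase TNNI3K (Homo sapiens) (on this read-out higher numbers stand for weaker inhibition and lower numbers for stronger inhibition), compound 1 reaches only a limit of the assay, <= 10 nM, and no number is known for it; the limit of <= 10 nM in this assay, at which 1 of the 3 values shown sits, marks this. Among the numbers that exist, compound 2 gives the lowest, 32 nM. Compound 3 gives 400 nM, a number higher than that of compound 2 and beyond the scatter of this assay.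

The step followed here goes from compound 2 to compound 4, `CNc1cc(Oc2ccc(NC(=O)Nc3cccc(C(F)(F)F)c3)cc2)ncn1`. The change is hydrogen in place of ethyl on a saturated chain carbon bound to a nitrogen on an aromatic ring. Cut one bond further out it reads propylamino to methylamino on the shared core. Within the data shown here, no measured pair in the set shows this same change, so no step size is on record for it.

Expectation: a small step, in either direction, likely within the scatter of this assay, as the alkylamino chain on the shared core is shortened and the urea and trifluoromethyl parts of compound 2 are kept. Compound 4 is estimated at 40 nM, within 15 nM to 120 nM, which means an expected step of a 1.3-fold higher number from compound 2 to compound 4 (0.10 log units; within the scatter).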

Compound 4, half-maximal inhibitory concentration: 40 nM
The estimate for compound 4 equals the measured number at the digits printed, within the range that was stated.
By their numbers in this assay, from the lowest: compounds 2 and 4 (each within the scatter of the next); then compound 3. At a limit, below all of these: compound 1.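

In this assay the alkylamino chain on the shared core can be shortened with no resolvable effect: the step is a 1.3-fold higher number from compound 2 to compound 4 (0.10 log units; within the scatter), so propylamino and methylamino cannot be told apart on this read-out. Compound 4 also gives compound 3 a partner that differs in one place, and in this assay the step is a 10-fold lower number from compound 3 to compound 4 (1.00 log units; beyond the scatter), with trifluoromethyl in place of fluoromethyl on an aromatic carbon. Among these compounds, of these two changes, only the one to trifluoromethyl moves the number beyond the scatter.

Going by these compounds, whether the same holds for a longer chain such as butyl, or for a free amino group at this place, remains open. Compound 1 stands only at a limit, and no step to it can be read: the limit of <= 10 nM in this assay, at which 1 of the 4 values shown sits.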